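A few compounds are considered here, and "the series" means these few. Any claim that something is new, unique, unknown or untested is made for them only; others in the source may bear on it.

Measured in a functional assay on cells (Ovarian carcinoma cell, Homo sapiens) for cytotoxicity, read by sulforhodamine B assay, with a stated time of 48 h; on this read-out higher numbers stand for weaker inhibition of growth and lower numbers for stronger inhibition of growth:
- compound 1 `COc1cc2c(cc1C)NC(=O)/C2=C/c1c(OC)nc2sc(C)cn12`: 47100 nM
- compound 2 `O=C1Nc2ccccc2C1=Cc1c(-c2ccncc2)nc2sccn12`: 61300 nM

Within the data shown here, compound 1 at 47100 nM lies within the scatter of compound 2 at 61300 nM, the only other number available, so the two cannot be told apart on this read-out. Compound 3 `COc1ccc2c(c1)/C(=C\c1c(OC)nc3sc(C)cn13)C(=O)N2` keeps the core of compound 1 and carries one change, hydrogen in place of methyl on an aromatic carbon, ortho to a methoxy group. Among the measured compounds shown here, no pair of measured compounds isolates this change, so the data give no direct size for it. In this assay, no step beyond the scatter is expected. The estimated 1.1-fold higher number from compound 1 to compound 3 (0.03 log units; within the scatter) reflects that expectation. For compound 3, the estimated value is 50000 nM, with an expected range of 22000 nM to 100000 nM.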

Compound 3, concentration for total growth inhibition: 42600 nM
Compound 3: middle estimate off by 1.2-fold (0.07 log units), on the high side; the range from low to high includes it.
By their numbers in this assay, from the lowest: compounds 3, 1 and 2 (each within the scatter of the next).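

Hydrogen in place of methyl on an aromatic carbon, ortho to a methoxy group, gives a 1.1-fold lower number from compound 1 to compound 3 (0.04 log units; within the scatter) in this assay and provides the first direct reading of this position. The methyl can therefore be exchanged for hydrogen without a step beyond the scatter, and compound 1 and compound 3 cannot be told apart on this read-out. No available data offer an explanation for this result.

At this position only methyl and hydrogen are shown, so the effect of a chlorine atom, an amine, a carboxylic acid or a longer chain such as propyl remains open. The methoxy group is common to compound 1 and compound 3, so what happens when it is exchanged for a hydroxyl group is also unresolved.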